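The compounds below may be only part of what the source reports. "The series", "measured", "known", "first", "only" and "open" are said of these compounds alone.

Compounds measured so far:
- Compound 1 `COC(=O)c1ccc(NCc2cncn2Cc2ccccc2)cc1-c1ccccc1`: > 1000 nM
- Compound 2 `COC(=O)c1ccc(NCc2cncn2Cc2ccccc2OC)cc1-c1ccccc1`: "not determined" (no result reported)
- Compound 3 `COC(=O)c1ccc(NCc2cncn2Cc2cccc(-c3ccccc3)c2)cc1-c1ccccc1`: "not determined" (no result reported)

In a toxicity assay on NIH3T3 cells (Mus musculus) for cytotoxicity, read by resazurin assay (a lower number here means that less compound is needed, a higher number that more compound is needed for the effect), compound 3 stands at "not determined" (no result reported), so it offers no single number as a starting point. Compound 2 likewise gives "not determined" (no result reported). Compound 1 gives > 1000 nM, which is a limit of the assay and not a number. Among the compounds with values here, that limit is the only reading, and no step between measured compounds is available.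

The next compound is compound 4 `COC(=O)c1ccc(NCc2cncn2Cc2ccccc2[N+](=O)[O-])cc1-c1ccccc1`. The change 2-nitrophenyl in place of 3-phenylphenyl on a saturated chain carbon bound to an aromatic nitrogen puts 2-nitrophenyl in place of 3-phenylphenyl on a saturated chain carbon bound to an aromatic nitrogen.

Within the data shown here, with so little to go on, no shift beyond the scatter is expected in this assay, in either direction, relative to the one reading available. This expectation rests solely on compound 1 with > 1000 nM, and compound 4 may well also be reported only as a limit.

For compound 4 the estimated value is 1500 nM, with an expected range from 500 nM to 5000 nM.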

Compound 4, half-maximal effective concentration: 10000 nM
The estimate for compound 4 lay 6.7-fold (0.82 log units) below the measured number; the measured number lies above the stated range.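

In this assay, within the data shown here, compound 1 gives > 1000 nM, which is a limit and not a number, so no step from compound 1 to compound 4 can be read. The compounds shown leave open whether nitro in place of hydrogen on an aromatic carbon changes the reading in this assay at all.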